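Piperidine for sulfamoylpiperazine on a fused pyridine core

The source may hold more compounds than are shown below. What is called first, only, known or untested is meant among the compounds shown, and "the series" means these compounds.

Measured so far:
compound 1 `COCC1CCN(c2c(S(=O)(=O)c3cc(F)cc(F)c3)cnc3cc(F)ccc23)CC1` — 83%
compound 2 `NS(=O)(=O)N1CCN(c2c(S(=O)(=O)c3cccc(F)c3)cnc3cc(F)ccc23)CC1` — 1.9%

In an assay on isolated protein for displacement of a labelled ligand from metabotropic glutamate receptor 5 (Homo sapiens), with a stated time of 60 min, tested at 1 uM (on this read-out lower numbers stand for less inhibition and higher numbers for more inhibition at the one concentration tested (going by the name of the read-out)), compound 2 gives 1.9%, the lowest of the two numbers, while compound 1 gives 83%, a gap that lies beyond the usual scatter. Compound 3 `COCC1CCN(c2c(S(=O)(=O)c3cccc(F)c3)cnc3cc(F)ccc23)CC1` has not yet been measured. It differs from compound 2 in one place: 4-(methoxymethyl)piperidin-1-yl in place of 4-sulfamoylpiperazin-1-yl on an aromatic carbon. The core of compound 2 and the (3-fluorophenyl)sulfonyl group stay as they are; only the amine on the aromatic carbon changes.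

Among the compounds with values here, no step between two measured compounds follows this exact change, so the expectation rests on compound 1, which carries the entering 4-(methoxymethyl)piperidin-1-yl group and gives 83% in this assay. Compound 3 is therefore expected to sit far above compound 2, with an estimated step of a number 68.1 percentage points higher from compound 2 to compound 3 (beyond the scatter), a rise well beyond the scatter. The estimate for compound 3 in this assay is 70%, with a range from 40% to 90%.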

Compound 3, a percentage reported as inhibition, at one concentration (the size of the read-out at that concentration, not a potency): 70.5%
Estimate against measurement, compound 3: 0.5 percentage points below, within the range that was stated.
By their numbers in this assay, from the lowest: compound 2; then compound 3; then compound 1.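

In this assay, 4-(methoxymethyl)piperidin-1-yl in place of 4-sulfamoylpiperazin-1-yl, on the aromatic carbon opposite the ring nitrogen, gives a number 68.6 percentage points higher from compound 2 to compound 3 (beyond the scatter), so with the (3-fluorophenyl)sulfonyl group held constant, the choice of amine at this position alone separates a low number from a much higher one. With 4-(methoxymethyl)piperidin-1-yl held constant, hydrogen in place of fluoro on an aromatic carbon gives a number 12.5 percentage points lower from compound 1 to compound 3 (beyond the scatter), a modest step and far smaller than the change of amine. The data give no measured account of why the amine change has so large a step.

The step from compound 2 to compound 3 changes the ring and its substituent together, so the compounds shown leave open whether the sulfamoyl group, the second ring nitrogen or the methoxymethyl group accounts for the difference. An unsubstituted piperidine, a piperazine without the sulfamoyl group or a 4-(hydroxymethyl)piperidine on the same core would begin to separate these parts.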